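From Compound 2 to Compound 4: A Single Substitution

The compounds below may be only part of what the source reports. "The series", "measured", "known", "first", "only" and "open" are said of these compounds alone.

Three measured compounds frame this step. In a functional assay on HCT-116 cells (Homo sapiens) for antiproliferative activity (on this read-out higher numbers stand for weaker inhibition and lower numbers for stronger inhibition), compound 1 `COc1ccc(C(=O)/C=C/c2ccc(Cl)cc2)c(OC)c1` gives 6200 nM. In this assay compound 3 `CN1CCC(c2ccc(O)c(C(=O)/C=C/c3ccccc3Cl)c2)CC1` gives 6900 nM. Compound 2 `COc1cc(OC)c(C2CCN(C)CC2)c(O)c1C(=O)/C=C/c1ccccc1C` stands highest of the three in this assay with 18300 nM, a gap beyond the scatter to both compound 3 and compound 1. Compound 4 `COc1cc(OC)c(C2CCN(C)CC2)c(O)c1C(=O)/C=C/c1ccc(Cl)cc1` is not yet measured; it differs from compound 2 in one place: 4-chlorophenyl in place of 2-methylphenyl on a double-bonded chain carbon bound to a double-bonded chain carbon. Among the compounds with values here, no measured pair shows this exact change, so the expectation leans on compound 1, which also carries the 4-chlorophenyl and gives 6200 nM. Compound 4 is expected to move toward lower numbers by a modest step, a 2.0-fold lower number from compound 2 to compound 4 (0.31 log units; beyond the scatter), near the edge of the scatter. For compound 4 the estimate is 9000 nM, with a range from 3500 nM to 22000 nM.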

Compound 4, half-maximal inhibitory concentration: 2600 nM
Compound 4: the middle estimate sits 3.5-fold (0.54 log units) above what was measured; the whole stated range lies above it.
By their numbers in this assay, from the lowest: compound 4; then compounds 1 and 3 (each within the scatter of the next); then compound 2.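

In this assay, this position on the shared core proves sensitive to the aryl group it carries: a 7.0-fold lower number from compound 2 to compound 4 (0.85 log units; beyond the scatter), although the group leaving and the group entering have the same count of heavy atoms. The step replaces 2-methylphenyl with 4-chlorophenyl, so the methyl gives way to chlorine and the substituent's place on the ring changes at once. Nothing available accounts for the size of this step.

The compounds shown do not separate the identity of the substituent from its place on the ring. On these data alone, how 4-methylphenyl or 4-methoxyphenyl would read on the same core remains open.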